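The source may report more compounds than this note shows. Statements on the series, on what has been measured and on what is new or still open speak of the compounds shown alone.

In a functional assay on LN-229 cells (Homo sapiens) for antiproliferative activity, with a stated time of 72 h (a higher number here means a weaker inhibitor, a lower number a stronger inhibitor), three compounds with a shared core have been measured. Compound 1 `CCCC#Cc1cc([C@@H]2O[C@H](CO)[C@@H](O)[C@H]2O)n2ncnc(N)c12` gives 40 nM and compound 2 `Nc1ncnn2c([C@@H]3O[C@H](CO)[C@@H](O)[C@H]3O)cc(C#CC3CC3)c12` gives 30 nM, and the step between them is a 1.3-fold lower number from compound 1 to compound 2 (0.12 log units; within the scatter). Compound 3 `Nc1ncnn2c([C@@H]3O[C@H](CO)[C@@H](O)[C@H]3O)cc(-c3ccc(F)cc3)c12` gives 65600 nM, the highest number of the three. The steps to it are large: a 1600-fold higher number from compound 1 to compound 3 (3.21 log units; beyond the scatter) and a 2200-fold higher number from compound 2 to compound 3 (3.34 log units; beyond the scatter). Compound 4 `Nc1ncnn2c([C@@H]3O[C@H](CO)[C@@H](O)[C@H]3O)cc(-c3ccc(F)cc3F)c12` has not yet been measured. It differs from compound 3 by fluoro in place of hydrogen on an aromatic carbon, ortho to a large group, which turns 4-fluorophenyl into 2,4-difluorophenyl. The two large steps to compound 3 replace the whole group on the core, whereas this change keeps the ring and adds one fluoro. For the measured compounds named here, no measured step shows such an addition, so they give only indirect guidance, and no clear direction can be drawn from them. Only a small change is expected. The estimated step is a 1.3-fold lower number from compound 3 to compound 4 (0.12 log units; within the scatter). For compound 4 the expected value is 50000 nM, with an estimated range of 15000 nM to 130000 nM.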

Compound 4, half-maximal inhibitory concentration: 43500 nM
Beside the measured number, compound 4's estimate is 1.1-fold (0.06 log units) above it; the measured number falls inside the stated range.
By their numbers in this assay, from the lowest: compounds 2 and 1 (each within the scatter of the next); then compounds 4 and 3 (each within the scatter of the next).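

In this assay, a fluoro on an aromatic carbon ortho to a large group, which turns 4-fluorophenyl into 2,4-difluorophenyl, gives a 1.5-fold lower number from compound 3 to compound 4 (0.18 log units; within the scatter), so this position of the phenyl ring takes the added fluoro with no change that can be told from scatter. The gap to the alkynyl compounds stays large with the new group, at a 1500-fold higher number from compound 2 to compound 4 (3.16 log units; beyond the scatter) and a 1100-fold higher number from compound 1 to compound 4 (3.04 log units; beyond the scatter), so the second fluoro does nothing to close it. No evidence is available to explain either the small step or the large gaps.

The compounds shown leave open whether an amine or a carboxylic acid on this phenyl ring would behave as the fluoro does. They also leave open whether a ring joined through a triple bond, or a longer chain on that bond, would hold the low numbers of the alkynyl compounds.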